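Swapping Hydroxy for Isopropyl on the Aryl Ring

The compounds below may be only part of what the source reports. "The series", "measured", "known", "first", "only" and "open" are said of these compounds alone.

Of the compounds shown here, three built on one shared core have been measured in an assay on CHO cells for inhibition of Glucagon receptor (Homo sapiens), tested at 20 uM; a lower number here means less inhibition, a higher number more inhibition at the concentration tested (going by the name of the read-out). Compound 1 `CCCCCc1c(C(C)C)nc(C(C)C)c(CO)c1-c1ccccc1NC(C)=O` gives 13%, compound 2 `CCCCCc1c(C(C)C)nc(C(C)C)c(CO)c1-c1cccc2ccccc12` gives 6%, and compound 3 `CCCCCc1c(C(C)C)nc(C(C)C)c(CO)c1-c1ccc(O)cc1` gives 24%. On these numbers compound 3 stands highest: its gap to compound 1 and its wider gap to compound 2 both lie beyond the usual scatter. Compound 4 `CCCCCc1c(C(C)C)nc(C(C)C)c(CO)c1-c1ccc(C(C)C)cc1` differs from compound 3 in one place: isopropyl in place of hydroxy on an aromatic carbon. For the measured compounds named here, no two measured compounds differ from each other in only one place, so the data give no comparable step to lean on. In this assay a small step from compound 3 to compound 4 is expected, downward if anything, and likely within the scatter. Compound 4 is therefore estimated at 18%, with a range from 4% to 34%, which is the step of a number 6 percentage points lower from compound 3 to compound 4 (within the scatter) expected here.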

Compound 4, a percentage reported as inhibition, at one concentration (the size of the read-out at that concentration, not a potency): 34%
Estimate against measurement, compound 4: 16 percentage points below; measured number inside the range.
By their numbers in this assay, from the lowest: compounds 2 and 1 (each within the scatter of the next); then compounds 3 and 4 (each within the scatter of the next).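

In this assay, putting isopropyl in place of hydroxy on this aromatic carbon, para to a large group, gives a number 10 percentage points higher from compound 3 to compound 4 (within the scatter), so the two groups cannot be told apart here. The read-out thus holds up at this position when a group with one hydrogen-bond donor and one acceptor gives way to a larger carbon-only group with neither. Nothing measured here explains this closeness.

As far as these compounds go, whether an amine or a carboxylic acid at the same position would read alike remains open. So does the outcome for a longer chain there, such as hexyl.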